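This account rests on a few compounds, and the source may have more. Where it says the series, first, only, none or still open, it means among the compounds named here.

Compound 1 `C=CC(=O)Nc1cccc(Nc2nc(N/N=C/c3ccc(F)cc3)ncc2Cl)c1` in an ADME assay on HT-29 cells (Homo sapiens) for inhibition, read by MTT assay, with a stated time of 72 h (a higher number here means a weaker inhibitor, a lower number a stronger inhibitor), gives 6340 nM. Compound 2 `C=CC(=O)Nc1cccc(Nc2nc(N/N=C/c3cn(Cc4ccccc4)c4ccccc34)ncc2Cl)c1` in this assay gives 11000 nM. Compound 3 `CN(C)C/C=C/C(=O)Nc1cccc(Nc2nc(N/N=C/c3ccc(F)cc3)ncc2Cl)c1` in this assay gives 3300 nM.

Compound 3 has the lowest of the three numbers, yet its gap to compound 1 is within the scatter, and only compound 2 stands clearly higher. Going by the values given here, the one measured step, a 1.9-fold lower number from compound 1 to compound 3 (0.28 log units; within the scatter), concerns the amide side of the molecule and not the hydrazone end.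

Compound 4 `COc1ccc(/C(C)=N/Nc2ncc(Cl)c(Nc3cccc(NC(=O)/C=C/CN(C)C)c3)n2)cc1` differs from compound 3 at the other end: a group of 11 heavy atoms (9 carbon, 1 nitrogen, 1 oxygen; one six-membered aromatic ring of carbon only) in place of a group of 9 heavy atoms (7 carbon, 1 nitrogen, 1 fluorine; one six-membered aromatic ring of carbon only), on a nitrogen on an aromatic ring. Among the compounds with values here, no measured step covers this change. The nearest hint is that compound 1 and compound 2, which differ only at the same place, show numbers that lie beyond the scatter of each other, so this position can move the read-out. With no directed evidence, the step from compound 3 to compound 4 in this assay is expected to be modest, a 1.4-fold higher number from compound 3 to compound 4 (0.13 log units; within the scatter), with a wide range. Compound 4 is therefore estimated at 4500 nM, between 1500 nM and 13000 nM.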

Compound 4, half-maximal inhibitory concentration: 6830 nM
For compound 4 the middle estimate is 1.5-fold (0.18 log units) below the measured one; the range from low to high includes it.
By their numbers in this assay, from the lowest: compounds 3, 1, 4 and 2 (each within the scatter of the next, the first and the last beyond it).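

In this assay, the place on the nitrogen on an aromatic ring now has a measured step of its own, a 2.1-fold higher number from compound 3 to compound 4 (0.32 log units; beyond the scatter), seen with the 3-(dimethylamino)prop-1-en-1-yl amide in place rather than the vinyl amide of compound 1 and compound 2. That step is small, only just beyond the scatter, and it swaps fluorine for oxygen and adds carbon in a single change, so it cannot be assigned to either part alone. Nothing measured here accounts for it.

The compounds shown leave open how this place would respond to a group carrying an amine or a carboxylic acid on its aromatic ring. They also leave open whether the same change would give a similar step on the vinyl amide.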